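Ethyl in place of tert-butyl on compound 2

A few compounds are considered here, and "the series" means these few. Any claim that something is new, unique, unknown or untested is made for them only; others in the source may bear on it.

In a physicochemical assay for lipophilicity, measured as octanol-water partition (a lower number here means a more polar compound, a higher number a more lipophilic compound), compound 2 `CC(C)(C)c1ccc(/C=C/C(=O)N[C@@H]2O[C@H](CO)[C@@H](O)[C@H](O)[C@H]2O)cc1` gives 0.496. Compound 3 `C[C@@H]1C[C@@]1(C(=O)N[C@@H]1O[C@H](CO)[C@@H](O)[C@H](O)[C@H]1O)c1cccc2ccccc12` gives 0.255, which is within the scatter of compound 2. Compound 1 `O=C(C[C@H]1CC(=O)c2c(F)cc(F)cc21)N[C@@H]1O[C@H](CO)[C@@H](O)[C@H](O)[C@H]1O` gives -1.21, lower than compound 2 and beyond the scatter. Compound 4 `CCc1ccc(/C=C/C(=O)N[C@@H]2O[C@H](CO)[C@@H](O)[C@H](O)[C@H]2O)cc1` has ethyl in place of tert-butyl on an aromatic carbon. No measured pair among these compounds shows a change in one place, so the size of the step is a judgement. A step toward the polar end of this assay, beyond the scatter, is expected. The estimated step is a number 0.70 log units lower from compound 2 to compound 4 (beyond the scatter). For compound 4 the expected value is -0.2, with an estimated range from -0.55 to 0.1.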

Compound 4, partition coefficient: 0.04
The estimate for compound 4 lay 0.24 log units below the measured number, within the range that was stated.
By their numbers in this assay, from the lowest: compound 1; then compounds 4, 3 and 2 (each within the scatter of the next, the first and the last beyond it).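

Replacing tert-butyl with ethyl on this aromatic carbon, para to a large group, gives the first change in one place among these compounds, and in this assay it reads as a number 0.46 log units lower from compound 2 to compound 4 (beyond the scatter), a modest step. Within the data shown here, this position therefore registers in the read-out, which the earlier compounds, differing in several places at once, could not show. Nothing shown here gives a measured reason for the step. The compounds shown leave open how an amine, a carboxylic acid or a longer chain such as n-butyl would read at this same aromatic carbon.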